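The compounds below may be only part of what the source reports. "The series", "measured", "known", "first", "only" and "open" are said of these compounds alone.

Measured so far in a functional assay on HL-60 cells (Homo sapiens) for cytotoxicity, read by WST assay, with a stated time of 48 h; on this read-out higher numbers stand for an effect only at larger amounts of compound and lower numbers for an effect already at smaller amounts:

- compound 1 `O=C1OC[C@H](Cc2ccccc2)[C@H]1Cc1ccccc1OC(F)(F)F` gives 39000 nM
- compound 2 `COCOc1ccccc1C[C@H]1C(=O)OC[C@@H]1Cc1ccccc1` gives 76000 nM
- compound 3 `O=C1OC[C@H](Cc2ccccc2)[C@H]1Cc1ccc(OC(F)(F)F)cc1` gives 27000 nM

All three share one core; how the core of compound 3 differs from that of compound 1 is not broken down here. Compound 2 carries, relative to compound 1, the change (methoxymethyl in place of trifluoromethyl on an oxygen on an aromatic ring), and the step is a 1.9-fold higher number from compound 1 to compound 2 (0.29 log units; within the scatter).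

Compound 4 `COCOc1ccc(C[C@H]2C(=O)OC[C@@H]2Cc2ccccc2)cc1` has not yet been measured in this assay. Relative to compound 3 it carries methoxymethyl in place of trifluoromethyl on an oxygen on an aromatic ring, the same change seen between compound 1 and compound 2, at a place described in the same words. For the measured compounds named here, the earlier step is the only guide available for it; no second occurrence of the change has been measured.

Going by the values given here, for compound 4 the step of a 1.9-fold higher number from compound 3 to compound 4 (0.27 log units; within the scatter) is expected, a step of about the same size as the measured one, because the one measured example of this change is a 1.9-fold higher number from compound 1 to compound 2 (0.29 log units; within the scatter). Compound 4 is therefore estimated at 50000 nM, with a likely range from 25000 nM to 100000 nM.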

Compound 4, half-maximal effective concentration: 71000 nM
For compound 4 the middle estimate is 1.4-fold (0.15 log units) below the measured one; the range from low to high includes it.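

In this assay, methoxymethyl in place of trifluoromethyl on the oxygen gives a 2.6-fold higher number from compound 3 to compound 4 (0.42 log units; beyond the scatter). Set beside the earlier step, this does not show that the size of the change depends on the core, since the two steps agree within the scatter: the same change on two cores in this assay, a 1.9-fold higher number (0.29 log units; within the scatter) from compound 1 to compound 2 and a 2.6-fold higher number (0.42 log units; beyond the scatter) from compound 3 to compound 4, 1.3-fold (0.13 log units) apart, within the scatter of two such steps. For the compounds shown here, the change therefore carries over between these two cores at about the same size, but this rests on only two pairs, one of which lies within the scatter on its own, so it does not establish a rule for the series or explain the step.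

The compounds shown leave open whether the step would hold on a third core, and whether it would hold in any read-out other than this assay. They also leave open what an amine, a carboxylic acid or a longer chain would do in place of trifluoromethoxy or methoxymethoxy on the aromatic ring.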